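Benzamide in place of a diaryl urea on the pyrazole series

This account rests on a few compounds, and the source may have more. Where it says the series, first, only, none or still open, it means among the compounds named here.

Compound 1 `COc1cc(-c2nn(-c3cccc(NC(=O)Nc4ccc(Cl)c(Cl)c4)c3)cc2-c2ccncc2)ccc1Cl`: 550 nM
Compound 2 `COc1cc(-c2nn(-c3cccc(NC(=O)Nc4ccc(Cl)c(C(F)(F)F)c4)c3)cc2-c2ccncc2)ccc1Cl`: 690 nM

In a functional assay on PC-3 cells (Homo sapiens) for inhibition, read by sulforhodamine B assay, with a stated time of 48 h (on this read-out higher numbers stand for weaker inhibition and lower numbers for stronger inhibition), compound 2 gives 690 nM, the higher of the two numbers, but the step of a 1.3-fold higher number from compound 1 to compound 2 (0.10 log units; within the scatter) lies within the scatter. Compound 3 `COc1cc(-c2nn(-c3cccc(NC(=O)c4ccccc4)c3)cc2-c2ccncc2)ccc1Cl` differs from compound 2 by phenyl in place of (4-chloro-3-(trifluoromethyl)phenyl)amino on a carbonyl carbon. Among the measured compounds shown here, no measured step touches that part of the molecule; the only step known concerns the distal ring alone. The change removes the urea's second nitrogen and its substituted ring entirely, so a weaker inhibition is expected, with the step of a 4.3-fold higher number from compound 2 to compound 3 (0.64 log units; beyond the scatter) set as a guess. Compound 3 is therefore estimated at 3000 nM, within 800 nM to 15000 nM.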

Compound 3, half-maximal inhibitory concentration: 430 nM
Compound 3: the middle estimate sits 7.0-fold (0.84 log units) above what was measured, and the stated range ends above it.
By their numbers in this assay, from the lowest: compounds 3, 1 and 2 (each within the scatter of the next).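

In this assay, the larger change on the carbonyl carbon, with phenyl replacing the substituted phenylamino group, gives a 1.6-fold lower number from compound 2 to compound 3 (0.21 log units; within the scatter) and a 1.3-fold lower number from compound 1 to compound 3 (0.11 log units; within the scatter). Where the earlier pair varied only a substituent on the distal ring, these steps show that the whole urea nitrogen and its substituted ring can be exchanged for phenyl without a shift beyond the scatter. Nothing available explains this tolerance.

On these data alone, it remains open whether an amine or a carboxylic acid on the phenyl ring of compound 3 would hold the number in this assay. As far as these compounds go, a methyl in place of that phenyl also remains untested here.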